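Three Inactive Analogues and an Unmeasured Fourth

This account rests on a few compounds, and the source may have more. Where it says the series, first, only, none or still open, it means among the compounds named here.

Compound 1 `CCc1nnc(SCc2ccccc2)n1N1C(=O)c2ccccc2C1=O`, compound 2 `CCc1nnc(SCC(=O)c2ccc(Cl)cc2)n1N1C(=O)c2ccccc2C1=O` and compound 3 `CCCc1nnc(SCc2ccccc2)n1N1C(=O)c2ccccc2C1=O` were all tested in a functional assay on MKN-45 cells (Homo sapiens) for cytotoxicity, read by MTT assay, with a stated time of 48 h; on this read-out lower numbers stand for stronger inhibition and higher numbers for weaker inhibition. In this assay compound 1 returns only a limit, > 200000 nM. Compound 2 likewise returns only a limit, > 200000 nM. Compound 3 also returns only a limit, > 200000 nM. Because (the limit of > 200000 nM in this assay, at which 3 of the 3 values shown sit), the two measured steps cannot be sized: a step that the two limits leave unreadable from compound 1 to compound 2, and a step that the two limits leave unreadable from compound 1 to compound 3.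

Compound 2 differs from compound 1 in one place, ((4-chlorophenyl)carbonyl in place of phenyl on a saturated chain carbon bound to a sulfur). The cores of compound 1 and compound 3 differ by methyl in place of hydrogen on a saturated chain carbon, two bonds along the chain from an aromatic carbon. Compound 4 `CCCc1nnc(SCC(=O)c2ccc(Cl)cc2)n1N1C(=O)c2ccccc2C1=O` stands to compound 3 exactly as compound 2 stands to compound 1: the same change, ((4-chlorophenyl)carbonyl in place of phenyl on a saturated chain carbon bound to a sulfur), at the same place.

Compound 4 is therefore expected to behave like its three neighbours, with a step that the limit leaves unreadable from compound 3 to compound 4 in this assay. This expectation rests on compound 2, whose value in this assay is a limit, > 200000 nM. For compound 4 the estimate in this assay is 250000 nM, between 100000 nM and 1000000 nM, most probably again reported only as a limit.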

Compound 4, half-maximal inhibitory concentration: > 200000 nM
Compound 4 ended at the assay's limit; the forecaster's own chance of this, stated with the estimate: 85%; the middle value lies beyond the limit too.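

Neither the step from compound 3 to compound 4 nor the step from compound 2 to compound 4 can be read in this assay, because all the values share one limit: the limit of > 200000 nM in this assay, at which 4 of the 4 values shown sit.

The compounds shown leave open how far compound 1, compound 2, compound 3 and compound 4 each lie past that limit, and so whether either change alters the result in this assay.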